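A few compounds are considered here, and "the series" means these few. Any claim that something is new, unique, unknown or untested is made for them only; others in the source may bear on it.

Compound 1 `CC1(C)S[C@@H]2/C(=C\C(=O)c3ccco3)C(=O)N2[C@H]1C(=O)OC(c1ccccc1)c1ccccc1` was tested in a functional assay on OE19 cells (Homo sapiens) for cytotoxicity, read by MTT assay, with a stated time of 48 h (a higher number here means a weaker inhibitor, a lower number a stronger inhibitor), where compound 1 gives 54300 nM. Two further compounds were measured in the same way: compound 2 `CC1(C)[C@H](C(=O)OC(c2ccccc2)c2ccccc2)N2C(=O)/C(=C/C(=O)c3ccc([N+](=O)[O-])cc3)[C@H]2[S+]1[O-]` gives 92400 nM in this assay, and compound 3 `CC1(C)[C@H](C(=O)OC(c2ccccc2)c2ccccc2)N2C(=O)/C(=C/C(=O)c3ccc([N+](=O)[O-])cc3)[C@H]2S1(=O)=O` gives 95500 nM. The number for compound 1 is the lowest of the three, but its gaps to compound 2 and to compound 3 both fall within the scatter of repeated measurements, so no order among them can be read from these values. Going by the values given here, compound 2 and compound 3 also differ from compound 1 in more than one place, so no single step between measured compounds can be traced.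

The step to compound 4 `CC(=O)/C=C1/C(=O)N2[C@@H]1SC(C)(C)[C@@H]2C(=O)OC(c1ccccc1)c1ccccc1` is a single change: methyl in place of furan-2-yl on a carbonyl carbon, that is, (furan-2-yl)carbonyl becomes acetyl. Among the compounds with values here, no measured pair in this set shows such a change, so the expectation rests on compound 1 alone and on the narrow spread of all three values, all of which sit in a weak range. For compound 4 the expected step is a 1.5-fold higher number from compound 1 to compound 4 (0.17 log units; within the scatter), small and most likely within the scatter, if anything towards a higher number. Compound 4 is therefore estimated at 80000 nM, with a range from 30000 nM to 250000 nM.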

Compound 4, half-maximal inhibitory concentration: 51900 nM
Estimate against measurement, compound 4: 1.5-fold (0.19 log units) above, and the stated range covers the measured number.
By their numbers in this assay, from the lowest: compounds 4, 1, 2 and 3 (each within the scatter of the next).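

In this assay, going by these compounds alone, methyl in place of furan-2-yl on a carbonyl carbon gives a 1.0-fold lower number from compound 1 to compound 4 (0.02 log units; within the scatter), the first step in this set that can be read between two compounds differing in one place. At this position, the five-membered aromatic ring can therefore be replaced by a single methyl carbon on the core of compound 1 without a change that can be told from the scatter, so the furan-2-yl group is not required for the cytotoxicity seen at this level in these cells. No measurement shown here offers an explanation for this result.

The compounds shown leave open whether this tolerance extends to other groups on the same carbonyl carbon, such as an amine, a carboxylic acid or a longer chain like propyl. They also leave open whether any replacement at this position can move the number beyond the scatter, and whether the same swap would behave alike on the oxidised sulfur forms seen in compound 2 and compound 3.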